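From compound 2 to compound 4: adding a methoxy group

The compounds below may be only part of what the source reports. "The series", "measured", "known", "first", "only" and "open" are said of these compounds alone.

In a functional assay on DU-145 cells (Homo sapiens) for antiproliferative activity, read by trypan blue exclusion (a lower number here means a stronger inhibitor, a higher number a weaker inhibitor), compound 2 `COc1ccc(CS(=O)(=O)/C=C/c2ccc(F)cc2)cc1` gives 1250 nM and compound 3 `COc1ccc(CS(=O)(=O)/C=C/c2ccc(Cl)cc2)cc1` gives 2500 nM. The gap between them is a 2.0-fold higher number from compound 2 to compound 3 (0.30 log units; within the scatter), which lies within the scatter, so neither can be ranked above the other. Compound 1 `COc1ccc(/C=C/S(=O)(=O)Cc2ccc(OC)cc2)cc1` gives > 20000 nM, which is a limit of the assay and not a number. Both of the other compounds stand well clear of that limit, with steps of an at least 16-fold lower number from compound 1 to compound 2 (1.20 log units; beyond the scatter) and an at least 8.0-fold lower number from compound 1 to compound 3 (0.90 log units; beyond the scatter), each beyond the scatter.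

Compound 4 `COc1ccc(CS(=O)(=O)/C=C/c2ccc(F)cc2OC)cc1` is compound 2 with one change, methoxy in place of hydrogen on an aromatic carbon, ortho to a large group and meta to the fluoro group. Within the data shown here, no measured step makes this exact change. The nearest evidence is the pair of steps above, where a methoxy group gives way to a halogen, and the larger of them is an at least 16-fold lower number from compound 1 to compound 2 (1.20 log units; beyond the scatter). Those steps warn that a methoxy group can carry a cost, but compound 4 keeps its fluoro group, so they bear on it only indirectly. A small rise in the number is therefore expected, probably not beyond the scatter, and the estimate is a 1.6-fold higher number from compound 2 to compound 4 (0.20 log units; within the scatter). For compound 4 the expected value is 2000 nM, with an estimated range from 400 nM to 10000 nM.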

Compound 4, half-maximal inhibitory concentration: 10000 nM
Beside the measured number, compound 4's estimate is 5.0-fold (0.70 log units) below it; measured number inside the range.
By their numbers in this assay, from the lowest: compounds 2 and 3 (each within the scatter of the next); then compound 4. At a limit, above all of these: compound 1.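

In this assay, among these compounds, adding a methoxy group ortho to a large group and meta to the fluoro group gives an 8.0-fold higher number from compound 2 to compound 4 (0.90 log units; beyond the scatter), the first direct reading of what this change does at this position. The earlier steps shown here only swapped a methoxy group for a halogen at a different place, whereas here the halogen stays and the number still rises beyond the scatter, so a methoxy group on this ring carries a cost even with the fluoro group kept. Compound 4 still gives a true number, and the only compound at a limit of the assay is compound 1: the limit of > 20000 nM in this assay, at which 1 of the 4 values shown sits.

With a single group at this position, the compounds shown cannot tell whether the rise belongs to the methoxy group itself or to any substituent placed there, and a hydroxyl, a methyl or an amine at the same carbon would separate those readings. They also leave open whether the same methoxy group would cost as much alongside the chloro group of compound 3, and they offer no measured cause for the step.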